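This account rests on a few compounds, and the source may have more. Where it says the series, first, only, none or still open, it means among the compounds named here.

Working notes on the series.

Compound 1 `C=CC(=O)Nc1ccc(Cn2nc(-c3ccc(Oc4ccccc4)cc3)cc2C(=O)O)cc1` is the reference point. In a functional assay on Maver1 cells (Homo sapiens) for inhibition, read by luminescence and CellTiter-Glo, with a stated time of 72 h (a higher number here means a weaker inhibitor, a lower number a stronger inhibitor), compound 1 returns only the limit of the assay, > 60000 nM. Going by the values given here, compound 2 `C=CC(=O)Nc1ccc(Cn2nc(-c3ccc(Oc4ccccc4)cc3)cc2CO)cc1` in this assay gives 7000 nM, and the step of an at least 8.5-fold lower number from compound 1 to compound 2 (0.93 log units; beyond the scatter) is the one measured change in the set that moves beyond the scatter. Compound 3 `C/C=C/C(=O)N1CCCC(n2nc(-c3ccc(Oc4ccccc4)cc3)cc2CO)C1` also sits at the limit of this assay, > 60000 nM. Two of the three values therefore sit at the limit (the limit of > 60000 nM in this assay, at which 2 of the 3 values shown sit), and compound 1 stands at the limit rather than on a number.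

Compound 4 `C=CC(=O)Nc1cccc(Cn2nc(-c3ccc(Oc4ccccc4)cc3)cc2C(=O)O)c1` differs from compound 1 in one place only: 3-((vinylcarbonyl)amino)phenyl in place of 4-((vinylcarbonyl)amino)phenyl on a saturated chain carbon bound to an aromatic nitrogen. Among the compounds with values here, no measured step concerns this change; the single measured step, from carboxy to hydroxymethyl, does not bear on it. Compound 1 keeps the carboxy group in compound 4, and on the numbers shown nothing argues for a move away from the limit. Compound 4 is therefore expected to stay near the limit in this assay, 60000 nM (range 20000 nM to 200000 nM), the expected step being a number no higher from compound 1 to compound 4 (the limit leaves the size open).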

Compound 4, half-maximal inhibitory concentration: 37400 nM
Estimate against measurement, compound 4: 1.6-fold (0.21 log units) above, within the range that was stated.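

With the carboxy group kept, 3-((vinylcarbonyl)amino)phenyl in place of 4-((vinylcarbonyl)amino)phenyl gives an at least 1.6-fold lower number from compound 1 to compound 4 (0.20 log units; that floor lies within the scatter), so in this assay a carboxy compound can return a number, as compound 4 does with 37400 nM. Compound 1 gives > 60000 nM, which is a limit of the assay and not a number. The true size of this step stays open, and no gain beyond the scatter can be claimed, because one end of it rests on a limit: the limit of > 60000 nM in this assay, at which 2 of the 4 values shown sit.

Still open, going by these compounds, is whether 3-((vinylcarbonyl)amino)phenyl keeps or changes its effect when hydroxymethyl stands in place of carboxy. Also open, on these data alone, is how a primary amide or a methyl ester would read in place of the carboxy group, or a propanoyl amide in place of the vinylcarbonyl amide.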